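From an Anilino Carbamate to a Methylphenyl Ester

The source may report more compounds than this note shows. Statements on the series, on what has been measured and on what is new or still open speak of the compounds shown alone.

Three compounds have been measured in a functional assay on PC-3 cells (Homo sapiens) for antiproliferative activity, read by sulforhodamine B assay, with a stated time of 48 h, tested at 50 uM; a lower number here means less inhibition, a higher number more inhibition at the concentration tested (going by the name of the read-out):

compound 1, `CC1=CC[C@H](C(C)C)c2cc(C)c(OC(=O)Nc3ccccc3)cc21`, gives 93.2%
compound 2, `Cc1cc2c(C(C)C)ccc(C)c2cc1OC(=O)c1ccc([N+](=O)[O-])cc1`, gives 100%
compound 3, `COc1ccc(C(=O)Oc2cc3c(C)ccc(C(C)C)c3cc2C)cc1`, gives 10.4%

Compound 1 stands second highest of the three. Its nearest neighbour is compound 2, which lies within the scatter of it, while compound 3 lies far below, beyond the scatter. Within the data shown here, the one measured step, a number 89.6 percentage points lower from compound 2 to compound 3 (beyond the scatter), shows that a change on the ester's aromatic ring can move the read-out across almost its whole span.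

Compound 4, `CC1=CC[C@H](C(C)C)c2cc(C)c(OC(=O)c3cccc(C)c3)cc21`, shares the core of compound 1 and differs from it in a single place: 3-methylphenyl in place of anilino on a carbonyl carbon. Among the measured compounds shown here, no measured step covers this change directly; the step from compound 2 to compound 3 only shows how strongly the group on the carbonyl carbon can matter in this assay. A step of a number 38.2 percentage points lower from compound 1 to compound 4 (beyond the scatter) is therefore expected, with wide uncertainty in either direction. For compound 4 a value of 55% is estimated, between 10% and 95%.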

Compound 4, a percentage reported as inhibition, at one concentration (the size of the read-out at that concentration, not a potency): 38.6%
Estimate against measurement, compound 4: 16.4 percentage points above; measured number inside the range.
By their numbers in this assay, from the lowest: compound 3; then compound 4; then compounds 1 and 2 (each within the scatter of the next).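

In this assay, replacing anilino with 3-methylphenyl on a carbonyl carbon gives a number 54.6 percentage points lower from compound 1 to compound 4 (beyond the scatter), showing on the core of compound 1 that this position is sensitive to the group it carries. The exchange keeps the heavy-atom count and removes the hydrogen-bond donor of anilino, but it also turns the carbamate into an ester and adds a methyl group, and these changes cannot be separated with the compounds shown. Nothing measured here gives a reason for this step.

As far as these compounds go, it remains open whether an N-methylanilino group, which keeps the carbamate without the amide hydrogen, would stay near compound 1 or fall towards compound 4. An unsubstituted phenyl group on the same carbonyl carbon would likewise be needed to isolate the contribution of the methyl group.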